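Swapping fluoro for cyano on the aryl ring of compound 2

The source may hold more compounds than are shown below. What is called first, only, known or untested is meant among the compounds shown, and "the series" means these compounds.

Measured so far:
- compound 1, `O=C(N/N=C/c1ccc(Cl)cc1)c1cnccn1`: 64%
- compound 2, `O=C(N/N=C/c1ccccc1F)c1cnccn1`: 100%
- compound 3, `O=C(N/N=C/c1cccc(Br)c1)c1cnccn1`: 100%

These three share one core and differ only in the group on the outer aromatic ring. In an ADME assay on J774 cells (Mus musculus) for cytotoxicity, read by MTT assay, with a stated time of 48 h, tested at 100 ug/mL (a higher number here means a weaker effect of the compound at the concentration tested, a lower number a stronger effect), compound 2 gives 100%, the same as compound 3 at the digits printed and within the scatter of it; compound 1 stands well below both, beyond the scatter. So compound 2 sits at the top of the small set.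

Compound 4, `N#Cc1ccccc1/C=N/NC(=O)c1cnccn1`, has not been measured. It differs from compound 2 by cyano in place of fluoro on an aromatic carbon. Among the measured compounds shown here, no measured pair shows this particular change, so the expectation leans on the fact that both compound 2 and compound 3 reach the top of the range. The step of a number 8 percentage points lower from compound 2 to compound 4 (within the scatter) is expected to be small, likely within the scatter, perhaps slightly downward. Compound 4 is therefore estimated at 92%, between 65% and 100%.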

Compound 4, a percentage reported as activity, at one concentration (the size of the read-out at that concentration, not a potency): 75%
For compound 4 the middle estimate is 17 percentage points above the measured one, within the range that was stated.
By their numbers in this assay, from the lowest: compound 1; then compound 4; then compounds 2 and 3 (each within the scatter of the next).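

In this assay, cyano in place of fluoro on an aromatic carbon ortho to a large group gives a number 25 percentage points lower from compound 2 to compound 4 (beyond the scatter). Among the compounds shown here, this is the first step in the set that isolates one change, and it shows that the group at this position can alter the result, here towards a stronger effect on the cells. Nothing available explains the step. As far as these compounds go, whether an amine, a carboxylic acid or a methoxy group on this same carbon would behave like fluoro or like cyano remains open. So does whether cyano elsewhere on the ring would give a similar step.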